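Swapping a nitrile for a fluorine on the indole

A few compounds are considered here, and "the series" means these few. Any claim that something is new, unique, unknown or untested is made for them only; others in the source may bear on it.

Of the compounds shown here, three built on one shared core have been measured in an assay on RPMI-8226 cells for antagonist activity at P2X purinoceptor 7 (Homo sapiens), read by calcium flux; a lower number here means a stronger inhibitor, a higher number a weaker inhibitor. Compound 1, `Cc1ccc2ccn(CCCCN3CCN(C(c4ccccc4)c4ccccc4)CC3)c2c1`, gives 6500 nM. Compound 2, `Cc1cccc2ccn(CCCCN3CCN(C(c4ccccc4)c4ccccc4)CC3)c12`, gives 2300 nM in this assay. Compound 3, `N#Cc1ccc2c(ccn2CCCCN2CCN(C(c3ccccc3)c3ccccc3)CC2)c1`, gives 3800 nM in this assay, which places it second highest of the three numbers, nearest to compound 2 and furthest from compound 1, although both of those gaps lie within the usual scatter.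

Compound 4, `Fc1cccc2c1ccn2CCCCN1CCN(C(c2ccccc2)c2ccccc2)CC1`, carries 4-fluoro-1H-indol-1-yl in place of 5-cyano-1H-indol-1-yl on a saturated chain carbon, four bonds along the chain from an amine nitrogen in a ring. For the measured compounds named here, no measured pair exchanges a nitrile for a fluorine, so the guidance is indirect. The step of a 2.8-fold lower number from compound 1 to compound 2 (0.45 log units; beyond the scatter), which alters only the substitution pattern of the same ring system, is modest, while a 1.7-fold lower number from compound 1 to compound 3 (0.23 log units; within the scatter) and a 1.7-fold higher number from compound 2 to compound 3 (0.22 log units; within the scatter) show that exchanging a methyl for a nitrile stays within the scatter. All three measured numbers sit close together, and the new change is of the same kind as those already seen. Compound 4 is expected to show a 1.1-fold lower number from compound 3 to compound 4 (0.04 log units; within the scatter), a shift most likely within the scatter with no direction favoured. Compound 4 is therefore estimated at 3500 nM in this assay, with a range from 1500 nM to 8000 nM.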

Compound 4, half-maximal inhibitory concentration: 150 nM
Compound 4: middle estimate off by 23-fold (1.37 log units), on the high side; measured number outside the range, below it.
By their numbers in this assay, from the lowest: compound 4; then compounds 2, 3 and 1 (each within the scatter of the next, the first and the last beyond it).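

In this assay, the group on the saturated chain carbon, four bonds along the chain from an amine nitrogen in a ring, can matter far more than the first three compounds suggested, since their steps were modest or within the scatter. Putting 4-fluoro-1H-indol-1-yl in place of 5-cyano-1H-indol-1-yl gives a 25-fold lower number from compound 3 to compound 4 (1.40 log units; beyond the scatter), and the same group also stands clear of the other two, with a 15-fold lower number from compound 2 to compound 4 (1.19 log units; beyond the scatter) and a 43-fold lower number from compound 1 to compound 4 (1.64 log units; beyond the scatter), which makes compound 4 the strongest inhibitor of the four. No measurement available here bears on why this group behaves so differently.

This step changes both the group and its numbered place on the indole, so the compounds shown cannot say whether the fluorine or the 4-position carries the gain; 4-cyano-1H-indol-1-yl and 5-fluoro-1H-indol-1-yl would separate the two. Also open, going by these compounds, is whether another group at that place, such as 4-chloro-1H-indol-1-yl or 4-methoxy-1H-indol-1-yl, would match the fluorine, and whether the gain would survive a longer chain.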